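Compound 4: a smaller group replaces the amide of compound 1

The source may report more compounds than this note shows. Statements on the series, on what has been measured and on what is new or still open speak of the compounds shown alone.

Measured in a functional assay on Ehrlich cells (Mus musculus) for cytotoxicity, read by trypan blue exclusion, with a stated time of 2 h; a higher number here means a weaker inhibitor, a lower number a stronger inhibitor:
- compound 1 `Cc1ccc(C(=O)NC2=C(C#N)C(c3ccc(Cl)cc3Cl)C3=C(CCCC3=O)N2c2ccc(S(N)(=O)=O)cc2)cc1`: > 100 ug/mL (a limit)
- compound 2 `N#CC1=C(NC(=O)c2ccc([N+](=O)[O-])cc2)N(c2ccc(S(N)(=O)=O)cc2)C2=C(C(=O)CCC2)C1c1ccc(Cl)cc1Cl`: 50 ug/mL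
- compound 3 `NC1=C(C(=O)O)C(c2ccc(Cl)cc2Cl)C2=C(CCCC2=O)N1c1ccc(S(N)(=O)=O)cc1`: > 100 ug/mL (a limit)

Compound 1 sits at the limit of > 100 ug/mL in this assay, at which 2 of the 3 values shown sit, so its true value is not known. Compound 4 `CCO/C=N/C1=C(C#N)C(c2ccc(Cl)cc2Cl)C2=C(CCCC2=O)N1c1ccc(S(N)(=O)=O)cc1` departs from it thus: a group of 5 heavy atoms (3 carbon, 1 nitrogen, 1 oxygen; no ring) in place of a group of 10 heavy atoms (8 carbon, 1 nitrogen, 1 oxygen; one six-membered aromatic ring of carbon only), on a double-bonded ring carbon. Among the measured compounds shown here, the only measured step, an at least 2.0-fold lower number from compound 1 to compound 2 (0.30 log units; that floor lies within the scatter), alters the group that compound 4 loses, and its size is only a floor. Compound 3 also lacks that group and gives > 100 ug/mL, again a limit. No change beyond the scatter is therefore expected in this assay, and the expected step is a number no higher from compound 1 to compound 4 (the limit leaves the size open). For compound 4 the estimated value is 100 ug/mL, with an expected range from 45 ug/mL to 200 ug/mL.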

Compound 4, half-maximal inhibitory concentration: > 100 ug/mL
Compound 4: only a limit was reported (the forecaster's own chance of this, stated with the estimate: 60%); the middle value sits exactly at the limit.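

In this assay compound 4 gives > 100 ug/mL, which is a limit and not a number. Replacing the nitro-bearing amide with the smaller ringless group on this double-bonded ring carbon gives an at least 2.0-fold higher number from compound 2 to compound 4 (0.30 log units; that floor lies within the scatter). The step between the two limited compounds 1 and 4 cannot be read, and the new group joins most of the series at the ceiling of the test: the limit of > 100 ug/mL in this assay, at which 3 of the 4 values shown sit.

Still open, on these data alone, is whether a plain acetyl amide or a benzoyl amide carrying a chlorine on this carbon would give a value rather than a limit.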